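This account rests on a few compounds, and the source may have more. Where it says the series, first, only, none or still open, it means among the compounds named here.

Values in a functional assay on HL-60 cells (Homo sapiens), with a stated time of 2 days; a lower number here means a stronger inhibitor, a higher number a weaker inhibitor:
Compound 1 `O=C(NC1CCCCC1)c1nc[nH]c1C(=O)Nc1ccc(Cl)c(Cl)c1`: 33100 nM
Compound 2 `Cc1ccc(CNC(=O)c2[nH]cnc2C(=O)Nc2ccc(Cl)c(Cl)c2)cc1`: 21400 nM

Compound 2 stands level with compound 1, as their two values lie within the usual scatter of each other. Compound 3 `C[C@@H](NC(=O)c1[nH]cnc1C(=O)Nc1ccc(Cl)c(Cl)c1)C(=O)OC(C)(C)C` carries 1-(tert-butoxycarbonyl)ethyl in place of 4-methylbenzyl on an amide-type nitrogen. Going by the values given here, no measured step yet shows what a change at this nitrogen does, so no shift beyond the scatter is expected in this assay, in either direction. The expected change is a 1.1-fold lower number from compound 2 to compound 3 (0.03 log units; within the scatter). Compound 3 is estimated at 20000 nM, with an expected range of 7000 nM to 50000 nM.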

Compound 3, half-maximal inhibitory concentration: 4600 nM
Beside the measured number, compound 3's estimate is 4.3-fold (0.64 log units) above it; the whole stated range lies above it.
By their numbers in this assay, from the lowest: compound 3; then compounds 2 and 1 (each within the scatter of the next).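

In this assay, the group on this amide-type nitrogen can shift the number beyond the scatter: 1-(tert-butoxycarbonyl)ethyl in place of 4-methylbenzyl gives a 4.7-fold lower number from compound 2 to compound 3 (0.67 log units; beyond the scatter) and so sets the first measured effect at this position. The lower number comes with the six-membered aromatic ring gone, so that ring is not required on this nitrogen for this gain. No measured evidence links the step to any particular feature of the exchange.

The compounds shown do not separate the contributions of the tert-butyl ester and the defined stereocentre. A carboxylic acid in place of the tert-butyl ester, or the opposite stereocentre, would test each.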